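This account rests on a few compounds, and the source may have more. Where it says the series, first, only, none or still open, it means among the compounds named here.

Measured compounds:
- Compound 1 `O=S(=O)(Nc1ccc(-c2nc3ccccc3o2)cc1)c1ccc(Cl)c(C(F)(F)F)c1`: > 63000 nM
- Compound 2 `Cc1ccccc1S(=O)(=O)Nc1ccc2oc(-c3ccccc3)nc2c1`: > 63000 nM
- Compound 3 `O=S(=O)(Nc1ccc(-c2nc3ccccc3o2)cc1)c1cccc(O)c1`: > 63000 nM

In an assay on isolated protein for inhibition of malate dehydrogenase, mitochondrial (Sus scrofa), with stated times of 45 min and 30 min (a lower number here means a stronger inhibitor, a higher number a weaker inhibitor), compound 1 gives > 63000 nM, which is a limit of the assay and not a number. Compound 2 also gives only a limit, > 63000 nM. Compound 3 likewise reaches only a limit, > 63000 nM. So compound 1 stands nowhere in particular among the values shown: the limit of > 63000 nM in this assay, at which 3 of the 3 values shown sit, and none of the three compounds shows measurable inhibition.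

Compound 4 `O=S(=O)(Nc1ccc(-c2nc3ccccc3o2)cc1)c1ccc(F)c(C(F)(F)F)c1` has not yet been measured in this assay. It differs from compound 1 in one place: fluoro in place of chloro on an aromatic carbon. Because compound 1 sits at > 63000 nM, there is no measured number from which a step could be read, and no step between measured compounds is shown that would suggest how such a swap moves the read-out. The expectation is therefore that the step from compound 1 to compound 4, a step that the limit leaves unreadable from compound 1 to compound 4, is none beyond the scatter, most likely with compound 4 again returning only a limit. Compound 4 is expected to come out near 100000 nM, within a range from 30000 nM to 400000 nM.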

Compound 4, half-maximal inhibitory concentration: > 63000 nM
Compound 4 gave a limit, no number; the forecaster's own chance of this, stated with the estimate: 85%; the middle value does not contradict the limit.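

Compound 1 and compound 4 both return only a limit of the assay and not a number, so the swap of fluoro in place of chloro gives no readable step: the limit of > 63000 nM in this assay, at which 4 of the 4 values shown sit.

The compounds shown leave open whether any close relative gives a measurable number in this assay, and how such a swap would then move it.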